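A few compounds are considered here, and "the series" means these few. Any claim that something is new, unique, unknown or untested is made for them only; others in the source may bear on it.

Compound 3 `CC(C)CN1CCC(CNC(=O)c2cc(Cl)cc3[nH]cnc23)CC1` carries a chloro on an aromatic carbon and an isopropyl on the saturated chain carbon bound to an amine nitrogen in a ring. In an assay on membranes from striatum for binding affinity to 5-hydroxytryptamine receptor 4 (Rattus norvegicus) (on this read-out higher numbers stand for weaker inhibition and lower numbers for stronger inhibition), compound 3 gives 0.29 nM, the second highest of three numbers: compound 2 `CS(=O)(=O)NCCN1CCC(CNC(=O)c2cc(Cl)cc3[nH]cnc23)CC1` gives 0.11 nM, while compound 1 `CS(=O)(=O)NCCN1CCC(CNC(=O)c2cccc3[nH]cnc23)CC1`, without the chloro, gives 11.4 nM. The measured steps are a 100-fold lower number from compound 1 to compound 2 (2.02 log units; beyond the scatter) and a 2.6-fold higher number from compound 2 to compound 3 (0.42 log units; beyond the scatter). Compound 4 `CCCCCN1CCC(CNC(=O)c2cc(Cl)cc3[nH]cnc23)CC1` differs from compound 3 by butyl in place of isopropyl on a saturated chain carbon bound to an amine nitrogen in a ring. Among the compounds with values here, only the step from compound 2 to compound 3 touches this chain carbon, and it was modest despite the larger change in groups; exchanging one short chain for another is therefore expected to shift the number little, with a 1.0-fold higher number from compound 3 to compound 4 (0.01 log units; within the scatter) expected to stay within the scatter. Compound 4 is estimated at 0.3 nM, between 0.1 nM and 1 nM.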

Compound 4, inhibition constant: 0.54 nM
The estimate for compound 4 lay 1.8-fold (0.26 log units) below the measured number; low and high end bracket the measured number.
By their numbers in this assay, from the lowest: compound 2; then compounds 3 and 4 (each within the scatter of the next); then compound 1.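

Putting butyl in place of isopropyl on this chain carbon gives a 1.9-fold higher number from compound 3 to compound 4 (0.27 log units; within the scatter), so these two plain carbon chains cannot be told apart on this read-out. Propyl in place of methanesulfonamido gives a 4.9-fold higher number from compound 2 to compound 4 (0.69 log units; beyond the scatter), a modest step that shows this position also separates an all-carbon chain from the sulfonamide-bearing one, though far less than the chloro step did. Nothing measured here explains either step.

Going by these compounds, it remains open whether this tolerance would hold for a much longer chain. An amine or a carboxylic acid in this place is also untested among the compounds shown.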